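The compounds below may be only part of what the source reports. "The series", "measured", "known", "first", "only" and "open" are said of these compounds alone.

Compound 1, `Cc1cccc(CSc2cc(Cl)c(C)cc2S(=O)(=O)/N=C(\N)n2nccc2-c2ccccc2)c1`, gives 47000 nM.
Compound 2, `Cc1cc(-c2ccccc2)n(/C(N)=N/S(=O)(=O)c2cc(C)c(Cl)cc2SCc2cccc3ccccc23)n1`, gives 170000 nM.
Compound 3, `Cc1cc(S(=O)(=O)/N=C(\N)n2nccc2-c2ccccc2)c(SCc2cccc3ccccc23)cc1Cl`, gives 58000 nM.

All three were tested in a functional assay on MCF7 cells (Homo sapiens) for cytotoxicity, read by MTT assay, with a stated time of 72 h; on this read-out higher numbers stand for weaker inhibition and lower numbers for stronger inhibition. Compound 3 holds the second highest of the three numbers: compound 1 sits within the scatter of it, while the step of a 2.9-fold lower number from compound 2 to compound 3 (0.47 log units; beyond the scatter) is the only one beyond the scatter. Compound 4, `Cc1cc(S(=O)(=O)/N=C(\N)n2nccc2-c2ccccc2)c(SCc2ccccc2Cl)cc1Cl`, differs from compound 3 by 2-chlorophenyl in place of naphthalen-1-yl on a saturated chain carbon bound to a sulfur. Going by the values given here, one measured step bears on this place: a 1.2-fold higher number from compound 1 to compound 3 (0.09 log units; within the scatter), which stayed within the scatter when the group on that carbon was exchanged. On that basis the step from compound 3 to compound 4 is expected to be small as well, a 1.1-fold lower number from compound 3 to compound 4 (0.02 log units; within the scatter). Compound 4 is therefore estimated at 55000 nM, with a range from 25000 nM to 120000 nM.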

Compound 4, half-maximal inhibitory concentration: 24000 nM
For compound 4 the middle estimate is 2.3-fold (0.36 log units) above the measured one; the whole stated range lies above it.
By their numbers in this assay, from the lowest: compounds 4, 1 and 3 (each within the scatter of the next, the first and the last beyond it); then compound 2.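

Replacing naphthalen-1-yl with 2-chlorophenyl gives a 2.4-fold lower number from compound 3 to compound 4 (0.38 log units; beyond the scatter) in this assay, so the group on this saturated chain carbon can shift the number beyond the scatter. Replacing 3-methylphenyl with 2-chlorophenyl gives a 2.0-fold lower number from compound 1 to compound 4 (0.29 log units; within the scatter), so those two groups cannot be told apart here. Nothing available explains either step.

Going by these compounds, it remains open whether a carboxylic acid or an amine on the ring of this group would lower the number further. A longer chain between the sulfur and the ring is also untested among these compounds.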